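Benzyl Carbamate on a Methoxyphenyl Pyrazoline

The source may hold more compounds than are shown below. What is called first, only, known or untested is meant among the compounds shown, and "the series" means these compounds.

Three compounds were examined in a functional assay on HeLa cells (Homo sapiens) for antiproliferative activity, read by MTT assay, with a stated time of 48 h; a higher number here means a weaker inhibitor of growth, a lower number a stronger inhibitor of growth: compound 1 `CCCOC(=O)N1N=C(c2ccccc2)CC1c1cc(OC)c(OC)c(OC)c1`, compound 2 `COc1cc(C2CC(c3ccccc3)=NN2C(=O)OCc2ccccc2)cc(OC)c1OC` and compound 3 `CCCOC(=O)N1N=C(c2cccc(OC)c2)CC1c1cc(OC)c(OC)c(OC)c1`. In this assay compound 1 gives only a limit, > 10000 nM. Compound 2 likewise gives only a limit, > 10000 nM. Compound 3 too gives only a limit, > 10000 nM. The change from compound 1 to compound 2 is phenyl in place of ethyl on a saturated chain carbon bound to an oxygen next to a carbonyl group and produced a step that the two limits leave unreadable from compound 1 to compound 2. The cores of compound 1 and compound 3 differ by methoxy in place of hydrogen on an aromatic carbon, with a step that the two limits leave unreadable from compound 1 to compound 3. Compound 4 `COc1cccc(C2=NN(C(=O)OCc3ccccc3)C(c3cc(OC)c(OC)c(OC)c3)C2)c1` has not yet been measured; it differs from compound 3 by phenyl in place of ethyl on a saturated chain carbon bound to an oxygen next to a carbonyl group, the same change as that from compound 1 to compound 2, at the same place. The step from compound 3 to compound 4 is expected to be a step that the limit leaves unreadable from compound 3 to compound 4, an expectation that rests on (the limit of > 10000 nM in this assay, at which 3 of the 3 values shown sit). Compound 4 is therefore estimated at 15000 nM, most probably again a limit rather than a number.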

Compound 4, concentration for 50% growth inhibition: > 10000 nM
Compound 4 was reported as a limit (the forecaster's own chance of this, stated with the estimate: 85%); the middle value does not contradict the limit.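

In this assay compound 4 gives only a limit, > 10000 nM, so neither its step from compound 3 nor its step from compound 2 can be read. The compounds shown leave open whether either change alters growth inhibition at all: the limit of > 10000 nM in this assay, at which 4 of the 4 values shown sit.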